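This account rests on a few compounds, and the source may have more. Where it says the series, first, only, none or still open, it means among the compounds named here.

In a functional assay on PC-3 cells (Homo sapiens) for antiproliferative activity, read by MTT assay, with a stated time of 72 h (on this read-out higher numbers stand for weaker inhibition and lower numbers for stronger inhibition), compound 1 `CCCSc1nc(Cl)c2c(n1)N(CCNC(=O)OC(C)(C)C)C(C(=O)N1CCN(C)CC1)N2` gives only > 64000 nM, which is a limit of the assay rather than a number (the limit of > 64000 nM in this assay, at which 1 of the 3 values shown sits). Compound 2 `CCCSc1nc(Cl)c2c(n1)N(Cc1cccs1)C(C(=O)N1CCN(C)CC1)N2` gives 5020 nM. Compound 3 `CCCSc1nc(Cl)c2c(n1)N(Cc1ccccc1)C(C(=O)OCC)N2` gives 62500 nM.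

Compound 3 stands highest of the two numbers shown; compound 2 lies well below it. Compound 4 `CCCSc1nc(Cl)c2c(n1)N(Cc1ccccc1)C(C(=O)Nc1ccccc1)N2` differs from compound 3 by anilino in place of ethoxy on a carbonyl carbon. The only measured step, an at least 12-fold lower number from compound 1 to compound 2 (1.10 log units; beyond the scatter), concerns the group on the ring nitrogen, not the carbonyl carbon, so no measured step bears directly on this change, and its direction cannot be read from the shown compounds. A modest downward step is therefore expected, a 3.1-fold lower number from compound 3 to compound 4 (0.49 log units; beyond the scatter). Compound 4 is estimated at 20000 nM, expected between 4000 nM and 80000 nM.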

Compound 4, half-maximal inhibitory concentration: > 64000 nM
Compound 4: no number, only a limit (the forecaster's own chance of this, stated with the estimate: 25%); at least 3.2-fold (0.50 log units) between middle value and limit.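

On the carbonyl carbon, anilino in place of ethoxy gives an at least 1.0-fold higher number from compound 3 to compound 4 (0.01 log units; that floor lies within the scatter), so the added aromatic ring and amide hydrogen bring no lowering of the number in this assay here. Compound 4 gives > 64000 nM, which is a limit and not a number. This limit is now shared by a second compound: the limit of > 64000 nM in this assay, at which 2 of the 4 values shown sit.

From the compounds shown here alone, how far the true value of compound 4 lies past the limit remains unknown, so the full size of this step stays open. Also open, going by these compounds, is whether a carboxylic acid or a small alkyl amine on this carbonyl carbon would lower the number.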